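Fluoro for Methyl: A Small Change on Compound 2

The compounds below may be only part of what the source reports. "The series", "measured", "known", "first", "only" and "open" are said of these compounds alone.

The measured compounds:
Compound 1, `Cc1ccc(C2=NN(C3=NC(c4ccccc4)CS3)C(c3ccc4ccccc4c3)C2)cc1`: in a functional assay on BGC-823 cells (Homo sapiens) for inhibition, read by CCK-8 assay, with a stated time of 48 h (on this read-out higher numbers stand for weaker inhibition and lower numbers for stronger inhibition), compound 1 gives 8940 nM.
Compound 2, `Cc1ccc(C2=NN(C3=NC(=O)CS3)C(c3ccc4ccccc4c3)C2)cc1`: in this assay compound 2 gives 7790 nM.
Compound 3, `c1ccc(C2=NN(C3=NC(c4ccccc4)CS3)C(c3ccc4ccccc4c3)C2)cc1`: in this assay compound 3 gives 9620 nM.

Compound 2 has the lowest of the three numbers, yet all three lie within the scatter of one another, so no order can be read among them. The two measured steps are both small: a 1.1-fold lower number from compound 1 to compound 2 (0.06 log units; within the scatter) and a 1.1-fold higher number from compound 1 to compound 3 (0.03 log units; within the scatter).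

Compound 4, `O=C1CSC(N2N=C(c3ccc(F)cc3)CC2c2ccc3ccccc3c2)=N1`, has not yet been measured. It differs from compound 2 in one place: fluoro in place of methyl on an aromatic carbon. The step from compound 1 to compound 3, which also changes the methyl on the same aromatic carbon, bears most directly on this change, and it stayed within the scatter. The replacement of the ring group on the amine nitrogen in the step from compound 1 to compound 2 likewise moved little. For the measured compounds named here, nothing among the measured compounds points to a shift beyond the scatter in this assay for a fluoro in place of methyl here.

Compound 4 is therefore expected to give about 8000 nM, with a range from 4000 nM to 16000 nM, which means an estimated step of a 1.0-fold higher number from compound 2 to compound 4 (0.01 log units; within the scatter).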

Compound 4, half-maximal inhibitory concentration: 14900 nM
The estimate for compound 4 lay 1.9-fold (0.27 log units) below the measured number; measured number inside the range.
By their numbers in this assay, from the lowest: compounds 2, 1, 3 and 4 (each within the scatter of the next).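

In this assay, for the compounds shown here, the change from 4-methylphenyl to 4-fluorophenyl gives a 1.9-fold higher number from compound 2 to compound 4 (0.28 log units; within the scatter) and thus offers the first direct reading of fluoro in place of methyl on this aromatic carbon. Until then, the only change shown at this position was hydrogen in place of methyl, a 1.1-fold higher number from compound 1 to compound 3 (0.03 log units; within the scatter) with a different group on the amine nitrogen. The new step also stays within the scatter, so neither fluoro nor methyl can be favoured here, and no evidence shown offers an explanation for the step.

The compounds shown leave open whether a methoxy group, an amine or a carboxylic acid on this aromatic carbon would move the number beyond the scatter. They also leave open whether 4-fluorophenyl would read alike with the group that compound 1 carries on the amine nitrogen.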